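This account rests on a few compounds, and the source may have more. Where it says the series, first, only, none or still open, it means among the compounds named here.

Measured compounds:
- compound 1 `N#C/C(=C\c1c(F)c(F)c(F)c(F)c1F)C(=O)c1c[nH]c2ccccc12`: 30000 nM
- compound 2 `COc1ccc(CNC(=O)/C(C#N)=C/c2ccco2)cc1`: 29000 nM

Two compounds of the series have been run in a functional assay on DU-145 cells (Homo sapiens) for inhibition, read by MTT assay, with a stated time of 72 h; a lower number here means a stronger inhibitor of growth, a higher number a weaker inhibitor of growth. Compound 1 gives 30000 nM. Compound 2 gives 29000 nM. Compound 2 holds the lowest of the two numbers, but the gap to compound 1 lies within the scatter, so the two values show no separation and no order between them can be read. Going by the values given here, no single-point step between measured compounds is available, since compound 1 and compound 2 differ in more than one place.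

Compound 3 `COc1ccc(CNC(=O)/C(C#N)=C/c2ccc(-c3ccccc3)o2)cc1` is not yet measured. It derives from compound 2 by phenyl in place of hydrogen on an aromatic carbon, on an aromatic carbon of the five-membered aromatic ring with 1 oxygen. Among the compounds with values here, no measured pair reports the effect of this change, so the expectation rests on the shared scaffold alone. In this assay compound 3 is expected to land somewhat lower than compound 2, a step of a 1.9-fold lower number from compound 2 to compound 3 (0.29 log units; within the scatter) of modest size that may not clear the scatter. The estimate for compound 3 is 15000 nM, with a range from 4000 nM to 60000 nM.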

Compound 3, concentration for 50% growth inhibition: > 100000 nM
Compound 3: only a limit was reported (the forecaster's own chance of this, stated with the estimate: 15%); middle value at least 6.6-fold (0.82 log units) from the limit.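

In this assay compound 3 gives > 100000 nM, which is a limit of the assay and not a number. Phenyl in place of hydrogen on an aromatic carbon, next to the ring oxygen of the five-membered aromatic ring with 1 oxygen, gives an at least 3.4-fold higher number from compound 2 to compound 3 (0.53 log units; beyond the scatter), the first single-place step read in this series and one that moves towards weaker growth inhibition beyond the scatter. This position is therefore not indifferent to what sits on it, and the step has only a lower bound on its size because the reading of compound 3 stops at a limit: the limit of > 100000 nM in this assay, at which 1 of the 3 values shown sits.

One step at one position cannot show whether the loss belongs to the phenyl ring specifically or to any replacement of that hydrogen, a question that a methyl group or a chlorine atom at the same place, or a phenyl carrying an amine or a carboxylic acid, would bear on. From the compounds shown here alone, how far compound 3 truly lies from compound 2 also stays open, as does whether any group at this position can give a lower number than compound 2.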